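A few compounds are considered here, and "the series" means these few. Any claim that something is new, unique, unknown or untested is made for them only; others in the source may bear on it.

Measured in a functional assay on Hep 3B2 cells (Homo sapiens) for cytotoxicity, read by MTT assay; a higher number here means a weaker inhibitor, a lower number a stronger inhibitor:
- Compound 1 `COc1ccc(OC)c(C(=O)/C=C/c2ccco2)c1`: 19000 nM
- Compound 2 `COc1ccc(OC)c(C(=O)/C=C/c2ccoc2)c1`: 12000 nM
- Compound 3 `COc1ccc(OC)c(C(=O)/C=C/c2ccc(C)s2)c1`: 3400 nM

Compound 3 has the lowest number of the three, and its steps from both others lie beyond the scatter. Compound 4 `COc1ccc(OC)c(C(=O)/C=C/c2occc2Br)c1` carries 3-bromofuran-2-yl in place of 5-methylthiophen-2-yl on a double-bonded chain carbon bound to a double-bonded chain carbon.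

The nearest evidence is a 5.6-fold lower number from compound 1 to compound 3 (0.75 log units; beyond the scatter) and a 3.5-fold lower number from compound 2 to compound 3 (0.55 log units; beyond the scatter), both modest, while a 1.6-fold lower number from compound 1 to compound 2 (0.20 log units; within the scatter) stays within the scatter. No bromofuran has been measured, so these steps guide only the direction, and a smaller reversal is expected in this assay. The expected change is a 2.1-fold higher number from compound 3 to compound 4 (0.31 log units; beyond the scatter). Compound 4 is estimated at 7000 nM, with an expected range from 2500 nM to 20000 nM.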

Compound 4, half-maximal inhibitory concentration: 11000 nM
Compound 4: middle estimate off by 1.6-fold (0.20 log units), on the low side; the measured number falls inside the stated range.
By their numbers in this assay, from the lowest: compound 3; then compounds 4, 2 and 1 (each within the scatter of the next).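

In this assay, 3-bromofuran-2-yl does not match 5-methylthiophen-2-yl at this position, with a 3.2-fold higher number from compound 3 to compound 4 (0.51 log units; beyond the scatter), so compound 3 keeps the lowest number. Bromo in place of hydrogen on an aromatic carbon gives a 1.7-fold lower number from compound 1 to compound 4 (0.24 log units; within the scatter), and the change from furan-3-yl gives a 1.1-fold lower number from compound 2 to compound 4 (0.04 log units; within the scatter); both steps lie within the scatter, so this bromo group shows no clear effect on the furan compounds. Nothing available explains the difference between these groups.

As far as these compounds go, it remains open whether the lower number of compound 3 goes with its sulfur or its methyl. From the compounds shown here alone, how thiophen-2-yl, 5-methylfuran-2-yl or a pyridine ring would read at this place also remains open.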